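The compounds below may be only part of what the source reports. "The series", "measured", "known", "first", "only" and "open" are said of these compounds alone.

The series rests on a shared core, two examples of which have been examined in a functional assay on COLO 205 cells (Homo sapiens) for cytotoxicity, read by MTT assay, with a stated time of 24 h; a lower number here means a stronger inhibitor, a higher number a weaker inhibitor. Compound 1 `Cc1cccc(-c2nnc(SCCCN3CCN(c4ccccn4)CC3)[nH]2)c1` carries a methyl-substituted phenyl ring on the core and a pyridin-2-yl group on the amine nitrogen of the six-membered ring. In this assay compound 1 reaches only the limit > 300000 nM, not a number. Compound 2 `CCN1CCN(CCCSc2nnc(-c3ccccc3Cl)[nH]2)CC1` instead bears a chlorophenyl ring and an ethyl group on that amine nitrogen. In this assay compound 2 likewise sits at the limit > 300000 nM, again not a measured number. Where compound 2 stands is therefore set entirely by the limit of > 300000 nM in this assay, at which 2 of the 2 values shown sit.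

Compound 3 `Clc1ccccc1-c1nnc(SCCCN2CCN(c3ccccn3)CC2)[nH]1` keeps the chlorophenyl ring of compound 2 and differs from it in one place: pyridin-2-yl in place of ethyl on an amine nitrogen in a ring. For the measured compounds named here, no measured pair shows this change directly. Compound 1 already carries the pyridin-2-yl group and still gives only a limit, so compound 3 is expected to stay at the limit as well, an expected step of a number no higher from compound 2 to compound 3 (the limit leaves the size open) that is no change beyond the scatter. The estimate for compound 3 in this assay is 300000 nM, within 100000 nM to 1000000 nM.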

Compound 3, half-maximal inhibitory concentration: > 300000 nM
Compound 3 was reported as a limit (the forecaster's own chance of this, stated with the estimate: 85%); the middle value sits exactly at the limit.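

No step can be read between compound 3 and compound 1 or compound 2 in this assay, because all three compounds give a limit and not a number: the limit of > 300000 nM in this assay, at which 3 of the 3 values shown sit.

The compounds shown leave open what number any of them would reach in this assay, and whether exchanging ethyl for pyridin-2-yl or 3-methylphenyl for 2-chlorophenyl changes it.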